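Swapping an aryl ketone for acetoxy on the shared core

The source may hold more compounds than are shown below. What is called first, only, known or untested is meant among the compounds shown, and "the series" means these compounds.

Compound 1 `CC1(C)C=C(n2ccccc2=O)c2cc(C(=O)c3ccc(O)cc3)ccc2O1` was tested in a functional assay (aorta) with Rattus norvegicus as the target (on this read-out higher numbers stand for higher potency (the scale is a negative logarithm) and lower numbers for lower potency), and gives 6.65. Two close relatives differ from it only in the ring attached to the carbonyl carbon. Compound 2 `CC1(C)C=C(n2ccccc2=O)c2cc(C(=O)c3ccccc3C(F)(F)F)ccc2O1` gives 6.76, and compound 3 `CC1(C)C=C(n2ccccc2=O)c2cc(C(=O)c3c(F)cccc3F)ccc2O1` gives 6.97. Among these three numbers compound 1 stands lowest: the change a number 0.11 log units higher from compound 1 to compound 2 (within the scatter) is small, while a number 0.32 log units higher from compound 1 to compound 3 (beyond the scatter) is the only one beyond the scatter, and a number 0.21 log units higher from compound 2 to compound 3 (within the scatter) is again small.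

Compound 4 `CC(=O)Oc1ccc2c(c1)C(n1ccccc1=O)=CC(C)(C)O2` is not yet measured. It departs from compound 1 in a different way: acetoxy in place of (4-hydroxyphenyl)carbonyl on an aromatic carbon. For the measured compounds named here, none of the measured steps touches this part of the structure; they only vary the aryl ring on the carbonyl, and all of them moved the number by little. Going by the values given here, there is therefore no direct precedent, and the change here is larger, removing the whole (4-hydroxyphenyl)carbonyl group and leaving only acetoxy at that carbon. The expectation for compound 4 in this assay is a lower number, a number 0.75 log units lower from compound 1 to compound 4 (beyond the scatter). Compound 4 is estimated at 5.9, within a range from 5.2 to 6.6.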

Compound 4, logarithm of the reciprocal of the active concentration, log(1/C): 5.6
The estimate for compound 4 lay 0.30 log units above the measured number; low and high end bracket the measured number.
By their numbers in this assay, from the lowest: compound 4; then compounds 1, 2 and 3 (each within the scatter of the next, the first and the last beyond it).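

In this assay, putting acetoxy in place of (4-hydroxyphenyl)carbonyl on this aromatic carbon gives a number 1.05 log units lower from compound 1 to compound 4 (beyond the scatter), a far bigger shift than any seen so far, where the largest step among the aryl ketones is a number 0.32 log units higher from compound 1 to compound 3 (beyond the scatter). This position is therefore not indifferent to what sits on it: the aryl ring on the carbonyl could be exchanged among compounds 1, 2 and 3 with only small shifts, whereas replacing the whole aryl ketone with acetoxy goes with a large fall in the number. Nothing measured here bears on why the number falls.

This one step removes the aromatic ring and also replaces the ketone with an ester linkage, so the compounds shown cannot separate the contribution of the ring from that of the link joining it to the core. An acetyl group on the same carbon would keep the ketone without the ring, while a benzyl ether, an amine or a carboxylic acid there would show how other groups compare at this position.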